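A few compounds are considered here, and "the series" means these few. Any claim that something is new, unique, unknown or untested is made for them only; others in the source may bear on it.

Of the compounds shown here, two that share the same core have been measured in a physicochemical assay for lipophilicity; a lower number here means a more polar compound, a higher number a more lipophilic compound. Compound 1 `O=C(O)CC(NC(=O)CCCCc1ccc2c(n1)NCCC2)c1cncnc1` gives 1.2 in this assay. Among the measured compounds shown here, compound 2 `O=C(O)C[C@H](CCCCCCc1ccc2c(n1)NCCC2)c1cnc2ccccc2c1` gives 2.39 in this assay, the higher of the two numbers, and its gap to compound 1 lies beyond the usual scatter of such measurements; no step between these two is given, so only the two values themselves can be set side by side. Compound 3 `COc1ncc([C@@H](CCCCCCc2ccc3c(n2)NCCC3)CC(=O)O)cn1` has not yet been measured. It differs from compound 2 in a single place: 2-methoxypyrimidin-5-yl in place of quinolin-3-yl on a saturated chain carbon bound to two saturated chain carbons. For the measured compounds named here, no measured pair shows this exact exchange, so its effect must be judged from the groups that leave and enter. A clear fall in this assay is expected, estimated as a number 1.19 log units lower from compound 2 to compound 3 (beyond the scatter), rather than a change within the scatter. For compound 3 the estimated value in this assay is 1.2, expected to lie between 0.6 and 1.8.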

Compound 3, partition coefficient: 0.65
The estimate for compound 3 lay 0.55 log units above the measured number; the measured number falls inside the stated range.
By their numbers in this assay, from the lowest: compound 3; then compound 1; then compound 2.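

In this assay, putting 2-methoxypyrimidin-5-yl in place of quinolin-3-yl on a saturated chain carbon bound to two saturated chain carbons gives a number 1.74 log units lower from compound 2 to compound 3 (beyond the scatter). Among the compounds shown here, this is the first single-place step available, and it shows that exchanging the group at this position can move the number well beyond the scatter. The exchange replaces two fused rings with one ring and changes the hetero atoms and hydrogen-bond acceptors as well, but no measurement on hand explains the step.

The compounds shown leave open how much of the step belongs to the loss of the second ring, the added ring nitrogen or the methoxy group. A plain pyrimidin-5-yl or a pyridin-3-yl group at the same place would begin to separate these parts.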